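This account rests on a few compounds, and the source may have more. Where it says the series, first, only, none or still open, it means among the compounds named here.

Compound 1 `C/N=C(\NC#N)Nc1cccnc1` is the starting point. In a functional assay on the whole organism (blood, strain Wistar-Okamoto) with Rattus norvegicus as the target, with a stated time of 5 days (on this read-out higher numbers stand for an effect only at larger amounts of compound and lower numbers for an effect already at smaller amounts), compound 1 gives > 50 mg/kg, and that figure is a limit of the assay rather than a measured number (the limit of > 50 mg/kg in this assay, at which 1 of the 2 values shown sits). Within the data shown here, the only other compound with a value is compound 2 `CC(C)C/N=C(\NC#N)Nc1cccnc1`, which in this assay gives 20 mg/kg. Among the measured compounds shown here, the single measured step is an at least 2.5-fold lower number from compound 1 to compound 2 (0.39 log units; beyond the scatter), with isopropyl in place of hydrogen on a saturated chain carbon bound to a double-bonded nitrogen.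

Compound 3 `CC(C)CC/N=C(\NC#N)Nc1cccnc1` is not yet measured. It differs from compound 1 by isobutyl in place of hydrogen on a saturated chain carbon bound to a double-bonded nitrogen. For the measured compounds named here, this is the same kind of change as the step to compound 2, extended by one carbon along the chain, so the step to compound 2 is the only guide to its size and direction. On that basis a lower number, of roughly the size seen for compound 2, is expected for compound 3, namely an at least 2.5-fold lower number from compound 1 to compound 3 (0.39 log units; beyond the scatter). Compound 3 is therefore estimated to give 20 mg/kg in this assay, with a likely range from 8 mg/kg to 50 mg/kg.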

Compound 3, minimum effective dose: 20 mg/kg
Estimate against measurement, compound 3: no gap at the digits printed; low and high end bracket the measured number.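

In this assay, a second and larger group at this place on the saturated chain carbon bound to the double-bonded nitrogen also lowers the dose needed for an effect, with an at least 2.5-fold lower number from compound 1 to compound 3 (0.39 log units; beyond the scatter), so the gain seen earlier does not rest on isopropyl alone. Putting isobutyl in place of isopropyl at the same place gives no change at the digits printed from compound 2 to compound 3 (within the scatter), so the two groups cannot be told apart in this read-out, and over this pair, lengthening the chain brings no further gain. The value for compound 1 is a limit and not a number, and the full size of any step away from it remains unknown because of that: the limit of > 50 mg/kg in this assay, at which 1 of the 3 values shown sits.

The compounds shown do not tell whether a longer chain such as hexyl would hold this level, lose it or improve on it, so it remains unclear where the benefit of chain size ends. They also leave open how a ring such as cyclohexyl, or a chain ending in an amine or a carboxylic acid, would read at this place.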